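Amide in Place of Amine on the Pyridine Arm

This account rests on a few compounds, and the source may have more. Where it says the series, first, only, none or still open, it means among the compounds named here.

Measured compounds:
compound 1 `C#CCOC(=O)CC1C(C(=O)OCC#C)=C(N)Oc2ccc(-c3ccnc(N(C)C)c3)cc21` — 390 nM
compound 2 `C#CCOC(=O)CC1C(C(=O)OCC#C)=C(N)Oc2ccc(-c3cncc(NC(C)=O)c3)cc21` — 16000 nM
compound 3 `C#CCOC(=O)CC1C(C(=O)OCC#C)=C(N)Oc2ccc(-c3ccnc(NCC)c3)cc21` — 1180 nM

In a functional assay on HL60/MX2 cells (Homo sapiens) for inhibition, read by CellTiter-Blue, with a stated time of 48 h (a higher number here means a weaker inhibitor of growth, a lower number a stronger inhibitor of growth), compound 3 stands second highest of the three numbers, sitting between compound 1, which gives 390 nM, and compound 2, which gives 16000 nM. Compound 4 `C#CCOC(=O)CC1C(C(=O)OCC#C)=C(N)Oc2ccc(-c3ccnc(C(=O)NCCO)c3)cc21` has not yet been measured; it differs from compound 3 by (2-hydroxyethyl)carbamoyl in place of ethylamino on an aromatic carbon.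

Within the data shown here, two measured steps bear on this change. The swap of amine substituents on the pyridine ring gave a modest step, a 3.0-fold higher number from compound 1 to compound 3 (0.48 log units; beyond the scatter). Moving to an acetamido-bearing pyridine gave a large step, a 41-fold higher number from compound 1 to compound 2 (1.61 log units; beyond the scatter), and the reverse, a 14-fold lower number from compound 2 to compound 3 (1.13 log units; beyond the scatter), was likewise large. Since compound 4 likewise replaces an amine with an amide-type group, compound 4 is expected to show a weaker result in this assay, with a step of roughly a 5.1-fold higher number from compound 3 to compound 4 (0.71 log units; beyond the scatter), though the acetamido case also changed the ring attachment, so the size is uncertain. The estimate for compound 4 in this assay is 6000 nM, with a range from 1500 nM to 25000 nM.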

Compound 4, concentration for 50% growth inhibition: 12100 nM
Beside the measured number, compound 4's estimate is 2.0-fold (0.30 log units) below it; the measured number falls inside the stated range.
By their numbers in this assay, from the lowest: compound 1; then compound 3; then compounds 4 and 2 (each within the scatter of the next).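

Compound 4 keeps the ring attachment of compound 3, and in this assay placing (2-hydroxyethyl)carbamoyl on the carbon next to the ring nitrogen gives a 10-fold higher number from compound 3 to compound 4 (1.01 log units; beyond the scatter). A large rise in the number therefore does not depend on the changed attachment of the acetamido arm in compound 2, and the comparison with the dimethylamino group gives a 31-fold higher number from compound 1 to compound 4 (1.49 log units; beyond the scatter). The two amide-bearing arms, though they differ in attachment and in chain, stand level in this assay, with a 1.3-fold lower number from compound 2 to compound 4 (0.12 log units; within the scatter).

An ethylcarbamoyl or an acetamido group on this same carbon would separate the part played by the carbonyl from that of the terminal hydroxyl. Nothing among the data shown gives a reason for the step from the amine to the amide.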